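A few compounds are considered here, and "the series" means these few. Any claim that something is new, unique, unknown or untested is made for them only; others in the source may bear on it.

In a functional assay on Jurkat cells (Homo sapiens) for inhibition, read by CCK-8 assay, with a stated time of 48 h (a higher number here means a weaker inhibitor of growth, a lower number a stronger inhibitor of growth), compound 3 `COc1ccc(CNc2nc(Nc3ccc(N4CCN(C)CC4)cn3)ncc2Cl)cc1` gives 12900 nM and compound 1 `Cc1ccccc1Nc1nc(Nc2ccc(N3CCN(C)CC3)cn2)ncc1Cl` gives 8080 nM and these two values lie within the scatter of each other. Compound 2 `CN1CCN(c2ccc(Nc3ncc(Cl)c(NCc4ccc(F)cc4)n3)nc2)CC1` gives > 100000 nM as a limit of the assay and not a number. Compound 4 `CC(C)c1ccc(Nc2nc(Nc3ccc(N4CCN(C)CC4)cn3)ncc2Cl)cc1` is not yet measured and differs from compound 3 as counted in 4-isopropylphenyl in place of 4-methoxybenzyl on a nitrogen on an aromatic ring with 4-isopropylphenyl in place of 4-methoxybenzyl on a nitrogen on an aromatic ring. The closest guide is a 1.6-fold higher number from compound 1 to compound 3 (0.20 log units; within the scatter) within the scatter, with 4-methoxybenzyl in place of 2-methylphenyl at that place. Larger steps appear in an at least 12-fold higher number from compound 1 to compound 2 (1.09 log units; beyond the scatter) and in an at least 7.7-fold lower number from compound 2 to compound 3 (0.88 log units; beyond the scatter) but both involve the 4-fluorobenzyl of compound 2, and no measured compound carries 4-isopropylphenyl. Going by these compounds, no step beyond the scatter is therefore expected in this assay and the direction stays open. The estimate for compound 4 means an expected step within the scatter (a 1.6-fold lower number from compound 3 to compound 4 (0.21 log units; within the scatter)). The expected value for compound 4 is 8000 nM (estimated range 2000 nM to 30000 nM).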

Compound 4, concentration for 50% growth inhibition: 7530 nM
Compound 4: middle estimate off by 1.1-fold (0.03 log units), on the high side; measured number inside the range.
By their numbers in this assay, from the lowest: compounds 4, 1 and 3 (each within the scatter of the next). At a limit, above all of these: compound 2.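

In this assay, the steps of a 1.7-fold lower number from compound 3 to compound 4 (0.23 log units; within the scatter) and a 1.1-fold lower number from compound 1 to compound 4 (0.03 log units; within the scatter) show that this place, on a nitrogen on an aromatic ring, takes 4-isopropylphenyl with no change beyond the scatter. The oxygen of 4-methoxybenzyl can therefore be replaced by an all-carbon group, and compound 4 keeps a number within the scatter of compound 3 and of compound 1. Only the 4-fluorobenzyl group stands apart, but the large step of an at least 13-fold lower number from compound 2 to compound 4 (1.12 log units; beyond the scatter) starts from a limit of the assay and not a number: the limit of > 100000 nM in this assay, at which 1 of the 4 values shown sits.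

Going by these compounds, it remains open whether 4-fluorophenyl on the same nitrogen would stay with compound 2 at the limit or join compounds 1, 3 and 4. Also open, on these data alone, is how an amine or a carboxylic acid on the ring at this place would read in this assay.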